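The source may hold more compounds than are shown below. What is called first, only, known or untested is meant among the compounds shown, and "the series" means these compounds.

Measured so far in a functional assay on HT-29 cells (Homo sapiens) for inhibition, read by sulforhodamine B assay, with a stated time of 72 h; on this read-out lower numbers stand for stronger inhibition and higher numbers for weaker inhibition
- compound 1 `COc1cc2c(Nc3ccc(F)c(Cl)c3)ncnc2cc1OCCCCCCn1ccnc1[N+](=O)[O-]` gives 5630 nM
- compound 2 `COc1cc2c(Nc3cccc(Br)c3)ncnc2cc1OCCCCn1ccnc1[N+](=O)[O-]` gives 4020 nM

Compound 2 at 4020 nM stands within the scatter of compound 1, so the two values do not separate. Compound 3 `COc1cc2c(Nc3cccc(Br)c3)ncnc2cc1OCCCCCCn1ccnc1[N+](=O)[O-]` is not yet measured. It differs from compound 2 by 2-(2-nitro-1H-imidazol-1-yl)ethyl in place of 2-nitro-1H-imidazol-1-yl on a saturated chain carbon, four bonds along the chain from an oxygen on an aromatic ring on a saturated chain carbon, four bonds along the chain from an oxygen on an aromatic ring. Going by the values given here, no single-change step between measured compounds is available, so no step beyond the scatter is expected in this assay and no direction is favoured. The estimated move is a 1.2-fold higher number from compound 2 to compound 3 (0.08 log units; within the scatter) and stays small. The expected value for compound 3 is 4800 nM (estimated range 2000 nM to 11000 nM).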

Compound 3, half-maximal inhibitory concentration: 10500 nM
Compound 3: the middle estimate sits 2.2-fold (0.34 log units) below what was measured; the measured number falls inside the stated range.
By their numbers in this assay, from the lowest: compounds 2, 1 and 3 (each within the scatter of the next, the first and the last beyond it).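

In this assay, going by these compounds alone, 2-(2-nitro-1H-imidazol-1-yl)ethyl in place of 2-nitro-1H-imidazol-1-yl on this saturated chain carbon gives a 2.6-fold higher number from compound 2 to compound 3 (0.42 log units; beyond the scatter) and is the series' only step so far to pass the scatter, though its size is modest. With that longer chain fixed, 3-bromophenyl in place of 3-chloro-4-fluorophenyl gives a 1.9-fold higher number from compound 1 to compound 3 (0.27 log units; within the scatter) and so does not separate the two aryl groups. No measurement at hand accounts for the chain step.

As far as these compounds go, whether a longer chain would continue this move remains open. Also open, from the compounds shown here alone, is how an amine in place of the nitroimidazole would read in this assay.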